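Fluoro added to the acid analogue of a sulfone series

The source may hold more compounds than are shown below. What is called first, only, known or untested is meant among the compounds shown, and "the series" means these compounds.

Three compounds were measured in a functional assay on K562 cells (Homo sapiens) for cytotoxicity, read by trypan blue exclusion, with a stated time of 96 h; on this read-out lower numbers stand for stronger inhibition and higher numbers for weaker inhibition:

compound 1, `COC(=O)C(Nc1cc(CS(=O)(=O)/C=C/c2c(OC)cc(OC)cc2OC)ccc1OC)c1ccccc1`: 30 nM
compound 2, `COC(=O)C(Nc1cc(CS(=O)(=O)/C=C/c2c(OC)cc(OC)cc2OC)ccc1OC)c1ccc(F)cc1`: 800 nM
compound 3, `COc1cc(OC)c(/C=C/S(=O)(=O)Cc2ccc(OC)c(NC(C(=O)O)c3ccccc3)c2)c(OC)c1`: 15 nM

Compound 1 and compound 2 differ by fluoro in place of hydrogen on an aromatic carbon, and this change gave a 27-fold higher number from compound 1 to compound 2 (1.43 log units; beyond the scatter). Compound 3 carries a different core, differing from compound 1 by hydrogen in place of methyl on an oxygen next to a carbonyl group; that difference gave a 2.0-fold lower number from compound 1 to compound 3 (0.30 log units; within the scatter). Between compound 2 and compound 3 the data show a 53-fold lower number from compound 2 to compound 3 (1.73 log units; beyond the scatter).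

Compound 4, `COc1cc(OC)c(/C=C/S(=O)(=O)Cc2ccc(OC)c(NC(C(=O)O)c3ccc(F)cc3)c2)c(OC)c1`, has not been measured. It differs from compound 3 by fluoro in place of hydrogen on an aromatic carbon, the same change as that from compound 1 to compound 2, with the same placing on the ring. Because the earlier change gave a 27-fold higher number from compound 1 to compound 2 (1.43 log units; beyond the scatter), and because the two cores sit close together at a 2.0-fold lower number from compound 1 to compound 3 (0.30 log units; within the scatter), compound 4 is expected to show a step of a 27-fold higher number from compound 3 to compound 4 (1.43 log units; beyond the scatter) in this assay, of similar size to the earlier one. Compound 4 is therefore estimated at 400 nM, most likely between 100 nM and 1600 nM.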

Compound 4, half-maximal inhibitory concentration: 80 nM
The estimate for compound 4 lay 5.0-fold (0.70 log units) above the measured number; the measured number lies below the stated range.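

In this assay the fluoro change gives a higher number on both cores, here a 5.3-fold higher number from compound 3 to compound 4 (0.73 log units; beyond the scatter), but the size of the step does not carry over from the methyl ester to the acid: the same change on two cores in this assay, a 27-fold higher number (1.43 log units; beyond the scatter) from compound 1 to compound 2 and a 5.3-fold higher number (0.73 log units; beyond the scatter) from compound 3 to compound 4, 5.0-fold (0.70 log units) apart, beyond the scatter of two such steps. Seen from the other side, replacing the methyl ester with the acid gives a 10-fold lower number from compound 2 to compound 4 (1.00 log units; beyond the scatter) among the 4-fluorophenyl compounds, a step that differs from the one among the phenyl compounds, while the two changes together give a 2.7-fold higher number from compound 1 to compound 4 (0.43 log units; beyond the scatter): the same change on two cores in this assay, a 2.0-fold lower number (0.30 log units; within the scatter) from compound 1 to compound 3 and a 10-fold lower number (1.00 log units; beyond the scatter) from compound 2 to compound 4, 5.0-fold (0.70 log units) apart, beyond the scatter of two such steps. The direction of the fluoro step thus held on these two cores while its size did not, but a single pair on each core cannot show why the steps differ or how general the direction is.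

The compounds shown leave open whether chloro or methoxy in place of fluoro on the phenyl ring would show the same dependence on the core. They also leave open how a primary amide in place of the acid would behave with and without fluoro.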